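This account rests on a few compounds, and the source may have more. Where it says the series, first, only, none or still open, it means among the compounds named here.

Measured so far:
- Compound 1, `OCC#Cc1ccccc1C#Cc1ccccc1`: 20600 nM
- Compound 2, `OCCCCC#Cc1ccccc1C#Cc1ccccc1`: 150 nM
- Compound 3, `CSc1ccccc1C#Cc1ccccc1C#CCCCCO`: 1500 nM

These three compounds were tested in a functional assay on SF-295 cells (Homo sapiens) for cytotoxicity; on this read-out higher numbers stand for weaker inhibition of growth and lower numbers for stronger inhibition of growth. Compound 2 gives the lowest of the three numbers in this assay; its nearest neighbour is compound 3, separated by a 10-fold higher number from compound 2 to compound 3 (1.00 log units; beyond the scatter), and the furthest is compound 1, separated by a 140-fold lower number from compound 1 to compound 2 (2.14 log units; beyond the scatter).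

Compound 4, `OCCCCC#Cc1ccccc1C#Cc1ccc(C(F)(F)F)cc1`, has not yet been tested. It differs from compound 2 in one place: trifluoromethyl in place of hydrogen on an aromatic carbon, on an aromatic carbon of a six-membered aromatic ring of carbon only, para to a large group. Going by the values given here, of the two measured steps, only the one from compound 2 to compound 3 concerns a substituent entering an aromatic carbon of the core, and there the number rose by a 10-fold higher number from compound 2 to compound 3 (1.00 log units; beyond the scatter). The other step, from compound 1 to compound 2, changes the chain and says little about a ring substituent. On this slim basis a modest rise in the number is expected for compound 4, so compound 4 is estimated at 450 nM with a range of 150 nM to 1500 nM, meaning an expected step of a 3.0-fold higher number from compound 2 to compound 4 (0.48 log units; beyond the scatter).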

Compound 4, concentration for 50% growth inhibition: 19100 nM
For compound 4 the middle estimate is 42-fold (1.63 log units) below the measured one; the whole stated range lies below it.
By their numbers in this assay, from the lowest: compound 2; then compound 3; then compounds 4 and 1 (each within the scatter of the next).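

In this assay, trifluoromethyl in place of hydrogen on an aromatic carbon, para to a large group, gives a 130-fold higher number from compound 2 to compound 4 (2.10 log units; beyond the scatter). This is a far larger change than the only earlier ring substitution, which gave a 10-fold higher number from compound 2 to compound 3 (1.00 log units; beyond the scatter), so a single substituent on an aromatic carbon of compound 2 can cost much more than methylsulfanyl alone suggested. Nothing available here explains the size of this step.

The compounds shown hold no other group at this position, such as a fluorine atom, a methoxy group or an amine, and no trifluoromethyl on another ring carbon, so it stays open whether the loss belongs to this group or to this place. On these data alone, it is also open whether a longer chain would change the size of the step.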